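This account rests on a few compounds, and the source may have more. Where it says the series, first, only, none or still open, it means among the compounds named here.

Three compounds share the same indolyl ketone nitrile dienone framework and were tested in a functional assay on MCF7 cells (Homo sapiens) for cytotoxicity, read by sulforhodamine B assay, with a stated time of 48 h; a higher number here means a weaker inhibitor of growth, a lower number a stronger inhibitor of growth. Compound 1 `N#C/C(=C\C=C(/Cl)c1ccc(Br)cc1)C(=O)c1c[nH]c2ccccc12` gives 72500 nM in this assay. Compound 2 `COc1ccc(/C(Cl)=C/C=C(\C#N)C(=O)c2c[nH]c3ccccc23)cc1OC` gives 44200 nM. Compound 3 `COc1ccc(/C(Cl)=C/C=C(\C#N)C(=O)c2c(C)[nH]c3ccccc23)cc1OC` gives 29600 nM. Between compound 2 and compound 3 the only change is methyl in place of hydrogen on an aromatic carbon, and that change made a 1.5-fold lower number from compound 2 to compound 3 (0.17 log units; within the scatter). How the core of compound 1 differs from the core of compound 2 is not broken down here; their two values lie within the scatter of each other, while compound 3 gives a number beyond the scatter from compound 1.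

Compound 4 `Cc1[nH]c2ccccc2c1C(=O)/C(C#N)=C/C=C(\Cl)c1ccc(Br)cc1` has not yet been measured in this assay. It differs from compound 1 by methyl in place of hydrogen on an aromatic carbon, the same change, at the same kind of place, as that from compound 2 to compound 3. Because a 1.5-fold lower number from compound 2 to compound 3 (0.17 log units; within the scatter) stayed within the scatter, the same change on compound 1 is expected to give a 1.5-fold lower number from compound 1 to compound 4 (0.16 log units; within the scatter). On that basis compound 4 is estimated to give 50000 nM in this assay, most likely between 25000 nM and 100000 nM.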

Compound 4, concentration for 50% growth inhibition: 73900 nM
Compound 4: middle estimate off by 1.5-fold (0.17 log units), on the low side, within the range that was stated.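

In this assay, methyl in place of hydrogen on an aromatic carbon made a 1.0-fold higher number from compound 1 to compound 4 (0.01 log units; within the scatter), so on the core of compound 1 this change left no reading that stands out from the scatter. Set beside the earlier step, the change reads the same on both cores, as far as these values can tell: the same change on two cores in this assay, a 1.5-fold lower number (0.17 log units; within the scatter) from compound 2 to compound 3 and a 1.0-fold higher number (0.01 log units; within the scatter) from compound 1 to compound 4, 1.5-fold (0.18 log units) apart, within the scatter of two such steps. This shows that the change carried from one core to the other with no detectable difference, but since both steps stay within the scatter, it does not show that the methyl has a real effect on either core, nor that the same would hold on any core beyond these two.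

The compounds shown leave open whether a larger group at this place, such as ethyl, or a different kind of group, such as an amine or a carboxylic acid, would give a step beyond the scatter. They also leave open how the methyl would read on a core carrying fluorine in place of the bromine of compound 1.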